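Cyclopropyl for ethyl on the amide of compound 2

This account rests on a few compounds, and the source may have more. Where it says the series, first, only, none or still open, it means among the compounds named here.

Compound 2 `CCC(=O)Nc1ccc(N(C)c2cccc(OC)c2)cc1` gives 1 nM in an assay on isolated protein for binding affinity to melatonin receptor type 1A (Homo sapiens); on this read-out higher numbers stand for weaker inhibition and lower numbers for stronger inhibition. Among the two compounds measured it has the highest number; its nearest neighbour is compound 1 `COc1cccc(N(C)c2ccc(NC(C)=O)cc2)c1`, which gives 0.05 nM. For the measured compounds named here, the one step between them, a 20-fold higher number from compound 1 to compound 2 (1.30 log units; beyond the scatter), was a methyl in place of hydrogen on a saturated chain carbon bound to the carbonyl carbon.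

Compound 3 `COc1cccc(N(C)c2ccc(NC(=O)C3CC3)cc2)c1` differs from compound 2 by cyclopropyl in place of ethyl on a carbonyl carbon. Going by the values given here, no measured step follows exactly this change; the only step available, from compound 1 to compound 2, lengthened the same chain by one carbon and moved the number far beyond the scatter. Adding a further carbon and closing the chain into a three-membered ring is a different move, so that step gives a direction but not a firm size. The expectation for compound 3 is therefore a step of no change at the digits printed from compound 2 to compound 3 (within the scatter), i.e. a number close to that of compound 2, with the range kept wide.

Compound 3 is expected to give 1 nM in this assay, within 0.2 nM to 5 nM.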

Compound 3, inhibition constant: 12 nM
Beside the measured number, compound 3's estimate is 12-fold (1.08 log units) below it, and the stated range ends below it.
By their numbers in this assay, from the lowest: compound 1; then compound 2; then compound 3.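

In this assay the carbonyl carbon of the amide proved sensitive a second time, with a 12-fold higher number from compound 2 to compound 3 (1.08 log units; beyond the scatter) showing that cyclopropyl in place of ethyl is not a neutral exchange at this position. Measured from the smallest group of the three, the change amounts to a 240-fold higher number from compound 1 to compound 3 (2.38 log units; beyond the scatter) and is the widest gap among these compounds, so the number rises in the order methyl, ethyl, cyclopropyl, and none of the three goes against that order. Nothing available here accounts for this rise.

Cyclopropyl differs from ethyl both in its ring and in its size, so the compounds shown cannot separate whether the ring or the added carbon goes with the higher number, and an open-chain isopropyl or a cyclobutyl group on the same carbonyl carbon would bear on that question. They also leave open whether any group on this carbonyl carbon gives a lower number than the methyl of compound 1, and how a methoxymethyl or an aminomethyl group, which carries a heteroatom in place of plain carbon, would behave there.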